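Indoline series: carbamoyl in place of pyridinyl on the ring nitrogen

The compounds below may be only part of what the source reports. "The series", "measured", "known", "first", "only" and "open" are said of these compounds alone.

Measured so far:
compound 1, `O=C(Nc1ccc(Cl)cc1)C1(c2ccc3c(c2)CCN3c2ccccn2)CCC1` — 1.6 nM
compound 2, `COC(=O)N1c2ccc(C3(NC(=O)c4ccc(F)cc4)CC3)cc2[C@@H]2CC[C@@H]21` — 5.6 nM

Two compounds have numbers in an assay on HeLa cells for inhibition of Indoleamine 2,3-dioxygenase 1 (Homo sapiens); on this read-out higher numbers stand for weaker inhibition and lower numbers for stronger inhibition. Compound 1 has the lowest number of the two; compound 2 stands higher, and the gap between the two lies beyond the scatter.

Compound 3, `CCN(C(=O)N1CCc2cc(C3(C(=O)Nc4ccc(Cl)cc4)CCC3)ccc21)C(C)C`, is not yet measured. It differs from compound 1 in one place: ethyl(isopropyl)carbamoyl in place of pyridin-2-yl on a nitrogen on an aromatic ring in a ring. Going by the values given here, no step between two measured compounds follows this change, so its size is open. Compound 2 carries a carbamate on the same nitrogen and gives 5.6 nM, which shows that a carbonyl-bearing group on that nitrogen keeps the number in the same region.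

Compound 3 is therefore expected to stand a little higher than compound 1, with the step of a 3.1-fold higher number from compound 1 to compound 3 (0.49 log units; beyond the scatter) near the edge of the scatter. The estimate for compound 3 is 5 nM, with a range from 1.5 nM to 20 nM.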

Compound 3, half-maximal inhibitory concentration: 3.3 nM
The estimate for compound 3 lay 1.5-fold (0.18 log units) above the measured number, within the range that was stated.
By their numbers in this assay, from the lowest: compound 1; then compounds 3 and 2 (each within the scatter of the next).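

In this assay, the nitrogen on the aromatic ring of the core of compound 1 accepts a group with no ring: ethyl(isopropyl)carbamoyl in place of pyridin-2-yl gives a modest step (a 2.1-fold higher number from compound 1 to compound 3 (0.31 log units; beyond the scatter)). An aromatic ring on this nitrogen is therefore not required for a low number in this series, although the exchange does cost a step beyond the scatter. No measured evidence here accounts for the size of this step.

Going by these compounds alone, the single pair does not separate the contribution of the carbonyl from that of the ethyl and isopropyl groups, so dimethylcarbamoyl, acetyl and a pyrrolidine-derived urea on this nitrogen remain open. Also open, on these data alone, is whether the same exchange gives a step of similar size when the 4-chlorophenyl amide of the shared core is replaced by a 4-fluorophenyl amide.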